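Adding a Methoxy to the Core of Compound 1

The source may hold more compounds than are shown below. What is called first, only, known or untested is meant among the compounds shown, and "the series" means these compounds.

Of the compounds shown here, three sharing an indole-like core have been tested in a functional assay on T47D cells (Homo sapiens) for inhibition, read by sulforhodamine B assay, with a stated time of 48 h; a lower number here means a stronger inhibitor of growth, a higher number a weaker inhibitor of growth. Compound 1 `COc1ccc(-c2[nH]c3ccccc3c2/C=C(\C#N)S(=O)(=O)c2ccccc2)cc1` gives 533 nM in this assay, the lowest of the three numbers. Compound 2 `COc1ccc2[nH]c(-c3ccccc3)c(C=C(C#N)C#N)c2c1` carries a methoxy on the fused ring and two nitriles on the side chain, and in this assay compound 2 gives 2300 nM. Compound 3 `CCOC(=O)C(=Cc1c(-c2ccccc2)[nH]c2ccccc12)C(=O)OCC` carries two ethyl esters instead, and in this assay compound 3 gives 2700 nM. Both of these numbers stand well beyond the scatter above that of compound 1, so compound 1 is the strongest inhibitor of growth among the three.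

The unmeasured compound 4 `COc1ccc(-c2[nH]c3ccc(OC)cc3c2/C=C(\C#N)S(=O)(=O)c2ccccc2)cc1` keeps everything in compound 1 and adds one change: methoxy in place of hydrogen on an aromatic carbon. For the measured compounds named here, no pair of measured compounds differs only in this way, so the size of the step cannot be read from the data; compound 2 shows a methoxy on the fused ring together with other differences and a weaker number, which does not separate the effect of the methoxy itself. The expected step from compound 1 to compound 4 is therefore small, a 1.2-fold higher number from compound 1 to compound 4 (0.09 log units; within the scatter), not clearly beyond the scatter in either direction. Compound 4 is estimated at 650 nM, with a likely range from 250 nM to 1700 nM.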

Compound 4, concentration for 50% growth inhibition: 905 nM
Compound 4: middle estimate off by 1.4-fold (0.14 log units), on the low side; measured number inside the range.
By their numbers in this assay, from the lowest: compounds 1 and 4 (each within the scatter of the next); then compounds 2 and 3 (each within the scatter of the next).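

In this assay, for the compounds shown here, this position can now be read directly for the first time: hydrogen and methoxy on the same aromatic carbon are compared with nothing else altered, and the swap gives a 1.7-fold higher number from compound 1 to compound 4 (0.23 log units; within the scatter), a step that cannot be told apart from repeat-measurement noise. The methoxy adds two heavy atoms and one hydrogen-bond acceptor, with no ring and no net charge, on a six-membered aromatic ring of carbon only within the fused system, and this single pair shows that such an addition there leaves the growth-inhibition number within the scatter. No measurement at hand explains the size of this step.

On these data alone, it remains open whether a different group on this same carbon, such as an amine, a carboxylic acid or a longer chain like butoxy, would move the number beyond the scatter in either direction. Also open, as far as these compounds go, is whether methoxy would give a similarly small step on the other carbons of this ring, or on this carbon when the side chain carries two nitriles or two ethyl esters instead.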